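An isobutyl amide after three amides at the limit

The source may hold more compounds than are shown below. What is called first, only, known or untested is meant among the compounds shown, and "the series" means these compounds.

Compound 1 `CCCSc1nc(Cl)c2c(n1)N(Cc1ccccc1)C(C(=O)O)N2` — > 64000 nM
Compound 2 `CCCSc1nc(Cl)c2c(n1)N(Cc1ccccc1)C(C(=O)NCCNC(=O)OC(C)(C)C)N2` — > 64000 nM
Compound 3 `CCCSc1nc(Cl)c2c(n1)N(Cc1ccccc1)C(C(=O)N1CCN(C)CC1)N2` — > 64000 nM

In a functional assay on MGC-803 cells (Homo sapiens) for antiproliferative activity, read by MTT assay, with a stated time of 72 h (on this read-out higher numbers stand for weaker inhibition and lower numbers for stronger inhibition), compound 1 gives > 64000 nM, which is a limit of the assay and not a number. Compound 2 gives > 64000 nM, again a limit. Compound 3 gives > 64000 nM, once more a limit. The three compounds therefore share one limit, (the limit of > 64000 nM in this assay, at which 3 of the 3 values shown sit), and none of the changes among them can be read: a step that the two limits leave unreadable from compound 1 to compound 2, a step that the two limits leave unreadable from compound 1 to compound 3 and a step that the two limits leave unreadable from compound 2 to compound 3 are all left unreadable by the two limits. Compound 3 thus stands at the limit, with no number to set it apart from compound 1 or compound 2.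

Compound 4 `CCCSc1nc(Cl)c2c(n1)N(Cc1ccccc1)C(C(=O)NCC(C)C)N2` differs from compound 3 in one place: isobutylamino in place of 4-methylpiperazin-1-yl on a carbonyl carbon. Among the measured compounds shown here, no measured step bears readably on this change, since every step among the amides of this series ended at the limit. The expectation for compound 4 in this assay is therefore that the step that the limit leaves unreadable from compound 3 to compound 4 stays within the scatter, with the result most likely reported again as a limit. Compound 4 is estimated at 80000 nM, in a range from 30000 nM to 200000 nM.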

Compound 4, half-maximal inhibitory concentration: 58400 nM
Estimate against measurement, compound 4: 1.4-fold (0.14 log units) above, and the stated range covers the measured number.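

In this assay compound 4 gives 58400 nM, so on this carbonyl carbon the isobutylamino amide yields a number, and this is the only number among the four compounds shown. Compound 1, compound 2 and compound 3 each remain at a limit of the assay, and that limit is not a number: the limit of > 64000 nM in this assay, at which 3 of the 4 values shown sit. The steps to compound 4 therefore read only as floors: there is an at least 1.0-fold lower number from compound 3 to compound 4 (0.03 log units; that floor lies within the scatter) and an at least 1.0-fold lower number from compound 2 to compound 4 (0.03 log units; that floor lies within the scatter) and also an at least 1.0-fold lower number from compound 1 to compound 4 (0.03 log units; that floor lies within the scatter), so no gain beyond the scatter can be claimed for any of these changes, and the number may lie close to the limit shared by the other three.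

Going by these compounds, it remains open whether a longer alkyl chain, a cyclohexylamino group or a benzylamino group on this carbonyl carbon would give a clearly lower number than isobutylamino does. With compound 4 the only amide that gives a number, the compounds shown also cannot say whether the amide hydrogen matters, and compound 2 carries such a hydrogen as well yet stays at the limit.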